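The source may report more compounds than this note shows. Statements on the series, on what has been measured and on what is new or still open speak of the compounds shown alone.

Measured in a functional assay on A549 cells (Homo sapiens) for inhibition, read by sulforhodamine B assay, with a stated time of 48 h; a lower number here means a stronger inhibitor, a higher number a weaker inhibitor:
- Compound 1 `CCOC(=O)CO/N=C(/c1ccc(OC)c(OC)c1OC)c1cccc2ccccc12` gives 6720 nM
- Compound 2 `COc1ccc(C(OCc2ccccc2)c2cccc3ccccc23)c(OC)c1OC` gives 13500 nM
- Compound 3 `COc1ccc(/C(=C\c2ccc(F)cc2)c2cccc3ccccc23)c(OC)c1OC` reaches only a limit of the assay, > 20000 nM

In this assay compound 2 at 13500 nM sits within the usual scatter of compound 1 at 6720 nM and the two cannot be told apart. Compound 4 `COc1ccc(C(OCc2ccc(C)cc2)c2cccc3ccccc23)c(OC)c1OC` differs from compound 2 by methyl in place of hydrogen on an aromatic carbon, turning benzyl into 4-methylbenzyl (methyl in place of hydrogen on an aromatic carbon). Within the data shown here, no measured pair shows such a change, so in this assay no step beyond the scatter is expected, in either direction. The step expected is a 1.1-fold lower number from compound 2 to compound 4 (0.05 log units; within the scatter) and no more. For compound 4 the estimated value is 12000 nM with an expected range from 5000 nM to 20000 nM as the likely span.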

Compound 4, half-maximal inhibitory concentration: 15700 nM
The estimate for compound 4 lay 1.3-fold (0.12 log units) below the measured number; measured number inside the range.
By their numbers in this assay, from the lowest: compounds 1, 2 and 4 (each within the scatter of the next, the first and the last beyond it). At a limit, above all of these: compound 3.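

In this assay, turning benzyl into 4-methylbenzyl, with methyl in place of hydrogen on an aromatic carbon para to a large group, gives a 1.2-fold higher number from compound 2 to compound 4 (0.07 log units; within the scatter). Among these compounds, this position therefore takes the added methyl with no step that can be read. Little room for reading a higher number remains, because compound 3 already stands at a limit: the limit of > 20000 nM in this assay, at which 1 of the 4 values shown sits.

Still open, as far as these compounds go, is whether a different group at this place, such as an amine or a carboxylic acid, would move the number beyond the scatter. The same question stands for a longer chain.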